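Amino in place of hydroxy on a second core

A few compounds are considered here, and "the series" means these few. Any claim that something is new, unique, unknown or untested is made for them only; others in the source may bear on it.

compound 1 `Nc1nc(O)c2c(S(=O)(=O)c3ccc4ccccc4c3)cccc2n1` — 4.85
compound 2 `Nc1nc(N)c2cc(Sc3ccc(Cl)c(Cl)c3)ccc2n1` — 7.96
compound 3 `Nc1nc(O)c2cc(Sc3ccc(Cl)c(Cl)c3)ccc2n1` — 6.92

In an assay for inhibition of Dihydrofolate reductase (Homo sapiens) (on this read-out higher numbers stand for higher potency (the scale is a negative logarithm) and lower numbers for lower potency), compound 3 gives 6.92 and compound 2 gives 7.96. The change between them is amino in place of hydroxy on an aromatic carbon, and it yields a number 1.04 log units higher from compound 3 to compound 2 (beyond the scatter). Compound 1 gives 4.85 in this assay, the lowest of the three numbers; the difference between its core and the core of compound 3 is not broken down here.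

Compound 4 `Nc1nc(N)c2c(S(=O)(=O)c3ccc4ccccc4c3)cccc2n1` has not been measured. It differs from compound 1 by amino in place of hydroxy on an aromatic carbon, and since the two place descriptions agree word for word this is the same change as from compound 3 to compound 2. For the measured compounds named here, the step is expected to be a number 1.00 log units higher from compound 1 to compound 4 (beyond the scatter), set beside the earlier one because a number 1.04 log units higher from compound 3 to compound 2 (beyond the scatter) is the only measured instance of this change, on a different core. Compound 4 is therefore estimated at 5.85, between 5.2 and 6.5.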

Compound 4, logarithm of the reciprocal of the active concentration, log(1/C): 4.82
Compound 4: middle estimate off by 1.03 log units, on the high side; measured number below the stated range.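

In this assay the change of amino in place of hydroxy does not carry over from one core to the other at a constant size: the same change on two cores in this assay, a number 1.04 log units higher (beyond the scatter) from compound 3 to compound 2 and a number 0.03 log units lower (within the scatter) from compound 1 to compound 4, 1.07 log units apart, beyond the scatter of two such steps. On the second core the change reads as a number 0.03 log units lower from compound 1 to compound 4 (within the scatter), so the gain on the first core cannot be assumed for a new core in this series. For the compounds shown here, with only two cores, which differ in more than one place, the data do not show which difference between them goes with the size of the step, and they give no cause for it.

Still open, on these data alone, is whether a methoxy or a methylamino group in place of hydroxy would split between the two cores in the same way. Also open, as far as these compounds go, is which of the two steps a third core carrying the same pair would resemble.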